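The source may report more compounds than this note shows. Statements on the series, on what has been measured and on what is new or still open speak of the compounds shown alone.

Working notes on the series. Three compounds share a core carrying a diaryl-methyl group on a ring nitrogen and have been measured in an assay on isolated protein for inhibition of Aromatase (Homo sapiens), read by fluorescence and colorimetric assay, with a stated time of 30 min; a higher number here means a weaker inhibitor, a lower number a stronger inhibitor. Compound 1 `N#Cc1ccc(OCc2cn(C(c3ccc(C#N)cc3)c3ccc(C#N)cc3)nn2)cc1` gives 4640 nM, compound 2 `Cc1ccc(OCc2cn(C(c3ccc(C#N)cc3)c3ccc(C#N)cc3)nn2)cc1` gives 11000 nM, and compound 3 `CCCCCCc1cn(C(c2ccccc2)c2ccccc2)nn1` gives 14800 nM. Within the data shown here, the single one-place step measured so far, a 2.4-fold higher number from compound 1 to compound 2 (0.37 log units; beyond the scatter), is modest but beyond the scatter. Compound 3 gives the highest of the three numbers; its gap to compound 2 lies within the scatter, while its gap to compound 1 lies beyond it.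

The next compound, compound 4 `c1ccc(-c2cn(C(c3ccccc3)c3ccccc3)nn2)cc1`, differs from compound 3 in one place: phenyl in place of hexyl on an aromatic carbon. Among the measured compounds shown here, no measured step bears directly on this change; the only step in hand swaps cyano for methyl on a distal aromatic ring and says nothing about replacing a hexyl chain with a phenyl ring on the five-membered aromatic ring with 3 nitrogen. For the measured compounds named here, with no guiding precedent, no step beyond the scatter is expected from compound 3 to compound 4, so a 1.2-fold lower number from compound 3 to compound 4 (0.09 log units; within the scatter) is the estimate. For compound 4 in this assay the expected value is 12000 nM, with a range from 3500 nM to 40000 nM.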

Compound 4, half-maximal inhibitory concentration: 12900 nM
Beside the measured number, compound 4's estimate is 1.1-fold (0.03 log units) below it; the measured number falls inside the stated range.
By their numbers in this assay, from the lowest: compound 1; then compounds 2, 4 and 3 (each within the scatter of the next).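

In this assay, phenyl in place of hexyl on an aromatic carbon of the five-membered aromatic ring with 3 nitrogen gives a 1.1-fold lower number from compound 3 to compound 4 (0.06 log units; within the scatter) and so leaves the number within the scatter. Among these compounds, this is the first step read at this position, and the earlier step from cyano to methyl could not show it: here, with the plain diphenyl-bearing core of compound 3, an open chain of 6 heavy atoms and a six-membered aromatic ring of carbon only, also of 6 heavy atoms, are not told apart by this assay. No measurement in hand accounts for this result.

From the compounds shown here alone, it remains open whether a group of another kind at this position, such as an amine, a carboxylic acid or a chain longer than hexyl, would move the number beyond the scatter. Going by these compounds, it is also open whether phenyl in place of hexyl would give as small a step on a diaryl-methyl group carrying nitrile groups, as in compound 1, rather than on the plain one of compound 3.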